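Chloro in place of methyl: compound 3 to compound 4

A few compounds are considered here, and "the series" means these few. Any claim that something is new, unique, unknown or untested is made for them only; others in the source may bear on it.

Compound 1 `Cc1ccccc1NC(=O)Nc1cc(-c2cccc(C(=O)O)c2)ccc1Oc1ccccc1C(C)(C)C` gives 1000 nM in an assay on HeLa cells for inhibition of Indoleamine 2,3-dioxygenase 1 (Homo sapiens), with a stated time of 20 h; a higher number here means a weaker inhibitor, a lower number a stronger inhibitor. Compound 2 `CCc1ccccc1Oc1ccc(-c2ccc(OC)c(C(=O)O)c2)cc1NC(=O)Nc1ccc(C)cc1` gives 540 nM in this assay, and compound 3 `COc1ccc(-c2ccc(Oc3ccccc3C)c(NC(=O)Nc3ccc(C)cc3)c2)cc1C(=O)O` gives 840 nM in this assay. The only single-point step among these three, a 1.6-fold higher number from compound 2 to compound 3 (0.19 log units; within the scatter), stays within the scatter. Compound 3 therefore sits among numbers that do not separate from one another: its nearest is compound 1 and its furthest is compound 2, and both gaps lie within the scatter.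

Compound 4 `COc1ccc(-c2ccc(Oc3ccccc3Cl)c(NC(=O)Nc3ccc(C)cc3)c2)cc1C(=O)O` differs from compound 3 by chloro in place of methyl on an aromatic carbon. Among the compounds with values here, no measured step exchanges a methyl for a chloro, so nothing speaks directly to this change; the one step that alters the same part of the molecule, a 1.6-fold higher number from compound 2 to compound 3 (0.19 log units; within the scatter), was within the scatter. The expected step in this assay is accordingly a 1.1-fold lower number from compound 3 to compound 4 (0.02 log units; within the scatter), with no direction beyond the scatter. Compound 4 is estimated at 800 nM, within a range from 300 nM to 2200 nM.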

Compound 4, half-maximal inhibitory concentration: 830 nM
Compound 4: the middle estimate sits 1.0-fold (0.02 log units) below what was measured, within the range that was stated.
By their numbers in this assay, from the lowest: compounds 2, 4, 3 and 1 (each within the scatter of the next).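

Moving from 2-methylphenoxy to 2-chlorophenoxy, the exchange at this aromatic carbon, ortho to a large group, is a 1.0-fold lower number from compound 3 to compound 4 (0.01 log units; within the scatter) in this assay, so the read-out does not separate chloro from methyl here. Against the ethyl of compound 2, chloro gives a 1.5-fold higher number from compound 2 to compound 4 (0.19 log units; within the scatter), and with the earlier ethyl-to-hydrogen step on the chain this leaves ethyl, methyl and chloro at this place unresolved in the three compounds that carry them. Nothing measured bears on why these groups read alike.

The compounds shown leave open whether any group at this place moves the number beyond the scatter, for instance an amine, a carboxylic acid or a longer chain. Going by these compounds, whether the same holds for compound 1, which differs from these compounds in more than one place, also stays open.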